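What (4-methoxyphenyl)carbonyl might do for compound 4

This account rests on a few compounds, and the source may have more. Where it says the series, first, only, none or still open, it means among the compounds named here.

In a functional assay on HCT-116 cells (Homo sapiens) for inhibition, read by MTT assay, with a stated time of 48 h (on this read-out higher numbers stand for weaker inhibition and lower numbers for stronger inhibition), compound 3 (`COc1cc(-c2nnc(SCc3ccc(F)cc3)n2-c2ccc(N(C)C)cc2)cc(OC)c1OC`) gives only a limit (> 60000 nM), not a number. Compound 1 (`COc1cc(-c2nnc(SC)n2-c2ccc(N(C)C)cc2)cc(OC)c1OC`) also gives only a limit (> 60000 nM). Only compound 2 (`COc1ccc(CSc2nnc(-c3cc(OC)c(OC)c(OC)c3)n2-c2ccc(N(C)C)cc2)cc1`) gives a true number (1150 nM).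

Compound 4 (`COc1ccc(C(=O)CSc2nnc(-c3cc(OC)c(OC)c(OC)c3)n2-c2ccc(N(C)C)cc2)cc1`) differs from compound 3 in one place, on a saturated chain carbon bound to a sulfur, where (4-methoxyphenyl)carbonyl stands in place of 4-fluorophenyl ((4-methoxyphenyl)carbonyl in place of 4-fluorophenyl on a saturated chain carbon bound to a sulfur).

Among the measured compounds shown here, two measured steps bear on this change. Putting 4-methoxyphenyl on that carbon brought much stronger inhibition (an at least 52-fold lower number from compound 1 to compound 2 (1.71 log units; beyond the scatter)). Fluoro in place of methoxy on the aromatic carbon took it away again (an at least 52-fold higher number from compound 2 to compound 3 (1.71 log units; beyond the scatter)). The step with 4-fluorophenyl says little (a step that the two limits leave unreadable from compound 1 to compound 3).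

Compound 4 regains the methoxy group of compound 2 (1150 nM), so a return towards that number seems likely. For the measured compounds named here, no measured compound carries the carbonyl, however, so its effect is untested and the estimate stays wide. A large step towards stronger inhibition is therefore expected (an at least 24-fold lower number from compound 3 to compound 4 (1.38 log units; beyond the scatter)). Compound 4 is estimated at 2500 nM in this assay, with an expected range of 400 nM to 20000 nM.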

Compound 4, half-maximal inhibitory concentration: > 60000 nM
Compound 4: no number, only a limit; the forecaster's own chance of this, stated with the estimate: 15%; at least 24-fold (1.38 log units) between middle value and limit.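

Compound 2 carries 4-methoxyphenyl on a saturated chain carbon bound to a sulfur, compound 4 carries (4-methoxyphenyl)carbonyl there, and nothing else differs; in this assay this one change removes the measurable inhibition (an at least 52-fold higher number from compound 2 to compound 4 (1.71 log units; beyond the scatter)). The methoxy group therefore does not secure inhibition on its own: compound 4 keeps the 4-methoxyphenyl ring and still gives only a limit, so what stands on that chain carbon matters as well as the substituent on the ring. Among the compounds shown here, the steps from compound 1 and from compound 3 to compound 4 cannot be read, and compound 2 remains the only compound here with a true number, the others all sitting at one ceiling: the limit of > 60000 nM in this assay, at which 3 of the 4 values shown sit.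

As far as these compounds go, how much weaker compound 4 really is stays unknown, and the series cannot show whether the carbonyl itself or the longer link to the ring accounts for the loss. A 2-(4-methoxyphenyl)ethyl group on the same carbon, which has the longer chain without the carbonyl, or a hydroxyl in place of the carbonyl oxygen, would help separate these two readings.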